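The source may report more compounds than this note shows. Statements on the series, on what has been measured and on what is new or still open speak of the compounds shown alone.

Measured compounds:
- Compound 1 `Cc1noc(C)c1S(=O)(=O)N1CCC(N2CCC(C)CC2)CC1` — in an ADME assay on HCT-116 cells (Homo sapiens) for cytotoxicity, read by CellTiter-Glo, with a stated time of 72 h (a lower number here means a stronger inhibitor, a higher number a weaker inhibitor), compound 1 gives > 10000 nM, which is a limit of the assay.
- Compound 2 `CC1CCN(C2CCN(S(=O)(=O)c3nccn3C)CC2)CC1` — compound 2 gives > 10000 nM, again a limit.
- Compound 3 `CC1CCN(C2CCN(S(=O)(=O)c3cccnc3F)CC2)CC1` — compound 3 gives > 10000 nM, also a limit.

Compound 3 stands at the same limit as the other two; none of the three has a measured number, and the limit of > 10000 nM in this assay, at which 3 of the 3 values shown sit, notes that every value shown sits there. The steps a step that the two limits leave unreadable from compound 1 to compound 3 and a step that the two limits leave unreadable from compound 2 to compound 3 are therefore unreadable, as is a step that the two limits leave unreadable from compound 1 to compound 2.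

Compound 4 `CC1CCN(C2CCN(S(=O)(=O)c3ccc(Cl)nc3)CC2)CC1` differs from compound 3 only by 6-chloropyridin-3-yl in place of 2-fluoropyridin-3-yl on a sulfonyl sulfur. The ring type, atom count and acceptor count are unchanged; one halogen replaces another on the ring attached to the sulfonyl sulfur. No readable step bears on this change, and the three aryl variants at the sulfonyl sulfur all returned limits. The expected step that the limit leaves unreadable from compound 3 to compound 4 is therefore no change beyond the scatter, with compound 4 most likely reported at the same limit. The estimate for compound 4 is 15000 nM, between 8000 nM and 50000 nM.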

Compound 4, half-maximal inhibitory concentration: > 10000 nM
Compound 4 gave a limit, no number (the forecaster's own chance of this, stated with the estimate: 85%); the middle value is on the limit's open side.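

In this assay compound 4 gives > 10000 nM, which is a limit. The steps to compound 4 from compound 1, compound 2 and compound 3 therefore cannot be read: the limit of > 10000 nM in this assay, at which 4 of the 4 values shown sit.

The compounds shown leave open whether any group on the sulfonyl sulfur gives a measured number in this assay.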